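Dropping the Methyl: From Compound 3 to Compound 4

This account rests on a few compounds, and the source may have more. Where it says the series, first, only, none or still open, it means among the compounds named here.

Three carbamates sharing one core have been measured for growth inhibition. Compound 1 `COc1ccc(OC(=O)Nc2ccc([Se]C#N)cc2)cc1` gives 48500 nM in a functional assay on HTB-54 cells (Homo sapiens) for cytotoxicity, read by MTT assay, with a stated time of 72 h; a higher number here means a weaker inhibitor of growth, a lower number a stronger inhibitor of growth. Compound 2 `CCCCCCOC(=O)Nc1ccc([Se]C#N)cc1` gives 48500 nM in this assay. Compound 3 `Cc1ccc(OC(=O)Nc2ccc([Se]C#N)cc2)cc1` gives 44200 nM in this assay, the lowest of the three numbers, though its gaps to compound 1 and to compound 2 both lie within the scatter, so no ranking among the three can be drawn from them. Within the data shown here, the one single-point step recorded, a 1.1-fold lower number from compound 1 to compound 3 (0.04 log units; within the scatter), is within the scatter as well.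

Compound 4 `N#C[Se]c1ccc(NC(=O)Oc2ccccc2)cc1` differs from compound 3 in one place: hydrogen in place of methyl on an aromatic carbon. Among the measured compounds shown here, no measured step removes a substituent from this site; the only step on record, from compound 1 to compound 3, exchanges one group for another there and leaves the number unchanged within the scatter. The three measured values also sit in a narrow band although they carry different groups and, in compound 2, a different chain. Compound 4 is therefore expected to stay close to compound 3, with a 1.0-fold higher number from compound 3 to compound 4 (0.02 log units; within the scatter) as the estimated step, meaning no shift beyond the scatter in either direction. For compound 4 the expected value in this assay is 46000 nM, within a range from 28000 nM to 75000 nM.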

Compound 4, concentration for total growth inhibition: 50200 nM
Estimate against measurement, compound 4: 1.1-fold (0.04 log units) below, and the stated range covers the measured number.
By their numbers in this assay, from the lowest: compounds 3, 1, 2 and 4 (each within the scatter of the next).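

In this assay, taking the substituent away entirely from this aromatic carbon, para to a large group, gives a 1.1-fold higher number from compound 3 to compound 4 (0.06 log units; within the scatter) and, starting from the methoxy group, gives a 1.0-fold higher number from compound 1 to compound 4 (0.01 log units; within the scatter) in the same comparison. The earlier step only exchanged methoxy for methyl, whereas these two show that the number stays within the scatter with hydrogen at this place, so neither group is shown to be required for the read-out in this assay, and the change of hexyl to phenyl on the carbamate oxygen (a 1.0-fold higher number from compound 2 to compound 4 (0.01 log units; within the scatter)) likewise leaves compound 4 within the scatter of compound 2. No measurement is available that could explain why these numbers remain so close, and no cause can be assigned to this result.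

With every step among these compounds inside the scatter, it remains open whether any change at this aromatic carbon can move the number at all, for example an amine, a carboxylic acid or a chlorine atom in place of hydrogen. From the compounds shown here alone, it is equally open whether a longer chain than hexyl, or a phenyl group carrying a substituent elsewhere on its ring, would leave the number where it stands.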